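The compounds below may be only part of what the source reports. "The series", "measured", "known", "first", "only" and "open" are said of these compounds alone.

Measured so far in an ADME assay on microsomes from liver (Homo sapiens) for metabolic stability, read by LC-MS, tested at 0.5 uM; a lower number here means slower removal, a higher number faster removal of the compound:
- compound 1 `CCCCN(C(=O)c1ccc(C(F)(F)F)cc1)c1nnc(-c2ccc(F)c3[nH]ccc23)s1`: 48.6 uL/min
- compound 2 `CCCCN(C(=O)c1ccc(C(F)(F)F)cc1)c1nnc(-c2ccc(CN(C)C)cc2)s1`: 109 uL/min

Compound 2 gives the highest number of the two, with compound 1 the nearest, and the gap is a 2.2-fold higher number from compound 1 to compound 2 (0.35 log units; beyond the scatter), beyond the scatter.

Compound 3 `CCCCN(C(=O)c1ccc(C(F)(F)F)cc1)c1nnc(-c2ccc(CO)cc2)s1` is not yet measured. The change from compound 2 to compound 3 is hydroxy in place of dimethylamino on a saturated chain carbon bound to an aromatic carbon.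

Among the measured compounds shown here, only one measured step exists, that from compound 1 to compound 2, and it alters a different part of the molecule, so no measured step bears directly on the change to compound 3. With nothing to go on beyond the two values, a step in this assay of no clear direction beyond the scatter is expected, with the wider uncertainty that an untested change carries. The estimated step is a 1.3-fold lower number from compound 2 to compound 3 (0.11 log units; within the scatter). Compound 3 is therefore expected to give about 85 uL/min, within a range of 40 uL/min to 170 uL/min.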

Compound 3, intrinsic clearance in a liver preparation (reported as CLH), per the amount of preparation that the assay uses: 61.2 uL/min
Beside the measured number, compound 3's estimate is 1.4-fold (0.14 log units) above it, and the stated range covers the measured number.
By their numbers in this assay, from the lowest: compounds 1, 3 and 2 (each within the scatter of the next, the first and the last beyond it).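

In this assay, hydroxy in place of dimethylamino on a saturated chain carbon bound to an aromatic carbon gives a 1.8-fold lower number from compound 2 to compound 3 (0.25 log units; within the scatter), so this first change at this position does not clear the scatter. Among the compounds shown here, the step between the 4-(hydroxymethyl)phenyl group and the group carried by compound 1 is a 1.3-fold higher number from compound 1 to compound 3 (0.10 log units; within the scatter), which also stays within the scatter, so only the step between compound 1 and compound 2 lies beyond it. No measurement bears on why the numbers fall as they do.

Still open, on these data alone, is whether a carboxylic acid, a methoxy group or a primary amine on the same carbon would give a step beyond the scatter. Also open, as far as these compounds go, is whether hydroxy in place of dimethylamino gives a similar step with a different group in place of the butyl chain.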